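Removing a Second Benzyl Group from a Weak Binder

The source may report more compounds than this note shows. Statements on the series, on what has been measured and on what is new or still open speak of the compounds shown alone.

Among the measured compounds shown here, compound 2 `CCOC(=O)C1=C(C)OC2OC(CO)C(OCc3ccccc3)C(OCc3ccccc3)C2[S+]1[O-]` stands at the higher of the two numbers so far obtained in an assay on CHO cells for displacement of a labelled ligand from Substance-K receptor (Homo sapiens); a lower number here means a stronger inhibitor, a higher number a weaker inhibitor. In this assay compound 2 gives 4000 nM. For the measured compounds named here, compound 1 `CCOC(=O)C1=C(C)OC2OC(COCc3ccccc3)C(OCc3ccccc3)C(O)C2[S+]1[O-]` differs from compound 2 in more than one place, so no single step connects them; in this assay compound 1 gives 790 nM, and the gap between the two values lies beyond the scatter.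

Compound 3 `CCOC(=O)C1=C(C)OC2OC(CO)C(OCc3ccccc3)C(O)C2[S+]1[O-]` arises from compound 2 by one change: hydrogen in place of benzyl on an oxygen on a saturated carbon, read one bond further out as benzyloxy to hydroxy. Going by the values given here, no measured pair isolates this change. Since compound 2 already sits at the weak end, the step is expected to be modest, most likely toward a higher number, though a step within the scatter cannot be excluded. The expected step is a 1.8-fold higher number from compound 2 to compound 3 (0.24 log units; within the scatter). In this assay compound 3 is estimated at 7000 nM, within a range from 1500 nM to 30000 nM.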

Compound 3, inhibition constant: > 10000 nM
Compound 3: no number, only a limit (the forecaster's own chance of this, stated with the estimate: 25%); middle value at least 1.4-fold (0.15 log units) from the limit.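

Compound 3 gives no number in this assay, only a limit: the limit of > 10000 nM in this assay, at which 1 of the 3 values shown sits. The earlier compounds shown here offered no single step, and now the same exchange of benzyl for hydrogen can be read at two different oxygens, giving an at least 2.5-fold higher number from compound 2 to compound 3 (0.39 log units; beyond the scatter) and also an at least 12-fold higher number from compound 1 to compound 3 (1.10 log units; beyond the scatter). Both steps point the same way and both lie beyond the scatter, so among the compounds shown, the loss of either benzyl group weakens binding, although the limit leaves the true size of each step unknown and the two cannot be ranked.

The compounds shown leave open whether the benzyl group itself matters or whether a smaller ether such as methyl on either oxygen would keep the binding. They also leave open how an amine or a carboxylic acid in that place would behave.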